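Dropping the nitro group from compound 3

A few compounds are considered here, and "the series" means these few. Any claim that something is new, unique, unknown or untested is made for them only; others in the source may bear on it.

- compound 1 `COc1ccc(-n2cc(COc3ccc(/C=C/C(C)=O)cc3OC)nn2)cc1` gives 21300 nM
- compound 2 `COc1cc(/C=C/C(C)=O)ccc1OCc1cn(-c2ccccc2OC)nn1` gives 25700 nM
- compound 3 `COc1cc(/C=C/C(C)=O)ccc1OCc1cn(-c2ccc([N+](=O)[O-])cc2)nn1` gives 96300 nM

In a functional assay on HCT-116 cells (Homo sapiens) for antiproliferative activity, read by MTT assay, with a stated time of 48 h (on this read-out lower numbers stand for stronger inhibition and higher numbers for weaker inhibition), compound 3 gives 96300 nM and carries the highest of the three numbers, which makes it the weakest so far. Compound 4 `COc1cc(/C=C/C(C)=O)ccc1OCc1cn(-c2ccccc2)nn1` differs from compound 3 by hydrogen in place of nitro on an aromatic carbon and this amounts to hydrogen in place of nitro on an aromatic carbon, para to a large group. Going by the values given here, no measured compound has a bare phenyl, so the replacement itself has not been observed.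

The nearest evidence comes from the steps that install the nitro group. These are a 4.5-fold higher number from compound 1 to compound 3 (0.66 log units; beyond the scatter) and a 3.7-fold higher number from compound 2 to compound 3 (0.57 log units; beyond the scatter) and both are modest but beyond the scatter. The methoxy pair differs by a 1.2-fold higher number from compound 1 to compound 2 (0.08 log units; within the scatter) and stays within the scatter. A single nitro compound is thin ground, but taking away the nitro group is expected to move the number back toward the methoxy pair, perhaps not all the way. The expected change is a 2.8-fold lower number from compound 3 to compound 4 (0.44 log units; beyond the scatter) in this assay and is a modest step toward a lower number.

For compound 4 the estimated value is 35000 nM with an expected range from 14000 nM to 85000 nM in this series.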

Compound 4, half-maximal inhibitory concentration: 67300 nM
Compound 4: middle estimate off by 1.9-fold (0.28 log units), on the low side, and the stated range covers the measured number.
By their numbers in this assay, from the lowest: compounds 1 and 2 (each within the scatter of the next); then compounds 4 and 3 (each within the scatter of the next).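

In this assay the change from 4-nitrophenyl to phenyl, on an aromatic carbon para to a large group, gives a step that stays within the scatter (a 1.4-fold lower number from compound 3 to compound 4 (0.16 log units; within the scatter)), so compounds 3 and 4 cannot be told apart and the nitro group alone does not account for their distance from the methoxy compounds. Hydrogen in place of methoxy gives steps beyond the scatter from both methoxy compounds (a 2.6-fold higher number from compound 2 to compound 4 (0.42 log units; beyond the scatter); a 3.2-fold higher number from compound 1 to compound 4 (0.50 log units; beyond the scatter)), so within these four compounds the separation follows the presence of methoxy on the phenyl ring, and none of the four goes against this reading. No data on any property of these compounds bear on why the steps fall this way.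

Four compounds cannot show whether this separation is particular to methoxy or would be shared by other groups on the phenyl ring, such as an ethoxy chain, a dimethylamino group or a chlorine atom. As far as these compounds go, it also remains open whether a carboxylic acid or a primary amine there would sit with compounds 3 and 4 or with the methoxy pair.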